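Swapping the Aminoethyl Arm for Pentan-3-yl

The source may hold more compounds than are shown below. What is called first, only, known or untested is meant among the compounds shown, and "the series" means these compounds.

Compound 1, `CCCn1c(=O)c2nc(C(C)C)[nH]c2n(CCC)c1=O`: 49 nM
Compound 2, `CCCn1c(=O)c2nc(C(C)N)[nH]c2n(CCC)c1=O`: 3000 nM
Compound 3, `CCCn1c(=O)c2nc(C(C)Cc3ccc(OC)cc3)[nH]c2n(CCC)c1=O`: 220 nM

In an assay on cell membranes for binding affinity to adenosine receptor A1 (Cavia porcellus) (a lower number here means a stronger inhibitor, a higher number a weaker inhibitor), compound 2 gives the highest number of the three measured compounds. Its nearest neighbour is compound 3: the record shows a 14-fold lower number from compound 2 to compound 3 (1.13 log units; beyond the scatter). Compound 1 stands furthest away, as a 61-fold higher number from compound 1 to compound 2 (1.79 log units; beyond the scatter) shows. Compound 1 and compound 3 are separated by a 4.5-fold higher number from compound 1 to compound 3 (0.65 log units; beyond the scatter).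

Compound 4, `CCCn1c(=O)c2nc(C(CC)CC)[nH]c2n(CCC)c1=O`, is the next one to be measured. Relative to compound 2 the change is pentan-3-yl in place of 1-aminoethyl on an aromatic carbon. Among the compounds with values here, two measured steps bear on it. The first is the arrival of the amino group in a 61-fold higher number from compound 1 to compound 2 (1.79 log units; beyond the scatter), a large rise. The second is its departure in a 14-fold lower number from compound 2 to compound 3 (1.13 log units; beyond the scatter), a large fall. In both cases the amino-bearing compound 2 carried the weaker number. Compound 4, like compound 1, holds a branched alkyl group free of any donor or acceptor, so the step from compound 2 to compound 4 is expected to be a large fall in this assay, of a size close to the reverse of the rise seen from compound 1 to compound 2; the step is estimated as a 50-fold lower number from compound 2 to compound 4 (1.70 log units; beyond the scatter). For compound 4 the expected value in this assay is 60 nM, within a range from 20 nM to 200 nM.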

Compound 4, inhibition constant: 19 nM
For compound 4 the middle estimate is 3.2-fold (0.50 log units) above the measured one, outside the stated range (below it).
By their numbers in this assay, from the lowest: compound 4; then compound 1; then compound 3; then compound 2.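

In this assay, the aromatic carbon between two ring nitrogen atoms proves able to carry a larger branched alkyl group than isopropyl without any loss: pentan-3-yl in place of isopropyl gives a 2.6-fold lower number from compound 1 to compound 4 (0.41 log units; beyond the scatter) in this series, a modest step but one beyond the scatter. The change from 1-aminoethyl to pentan-3-yl gives a 160-fold lower number from compound 2 to compound 4 (2.20 log units; beyond the scatter) and so is larger in size than a 61-fold higher number from compound 1 to compound 2 (1.79 log units; beyond the scatter) that came with the amino group, yet added bulk at this position does not always lower the number, as compound 3 goes against that trend with a 4.5-fold higher number from compound 1 to compound 3 (0.65 log units; beyond the scatter). Nothing measured here accounts for these differences.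

Going by these compounds, what remains open is how far the trend from isopropyl to pentan-3-yl runs, for instance with a longer branched chain such as heptan-4-yl or with a ring such as cyclopentyl at the same carbon. On these data alone, it is also open whether the high number of compound 2 belongs to an amine on that carbon in particular, or would also appear with a hydroxyl there or with an amine further out along a longer chain.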